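Methyl to Fluoro on the Amide Aryl Ring

The compounds below may be only part of what the source reports. "The series", "measured", "known", "first", "only" and "open" are said of these compounds alone.

Of the compounds shown here, three sharing one core have been measured in a functional assay on GTL 16 cells for antiproliferative activity against GTL 16 cell line (Homo sapiens), read by CCK-8 assay, with a stated time of 72 h; a higher number here means a weaker inhibitor, a lower number a stronger inhibitor. Compound 1 `O=C(Nc1cccc(-c2oc3cc(-c4ccc(F)cc4)ccc3c(=O)c2O)c1)c1ccccc1F` gives 17400 nM. Compound 2 `Cc1ccccc1C(=O)Nc1cccc(-c2oc3cc(-c4ccc(F)cc4)ccc3c(=O)c2O)c1` gives 24800 nM in this assay. Compound 3 `Cc1cccc(C(=O)Nc2cccc(-c3oc4cc(-c5ccc(F)cc5)ccc4c(=O)c3O)c2)c1` gives 10900 nM in this assay. The cores of compounds 2 and 3 differ by 3-methylphenyl in place of 2-methylphenyl on a carbonyl carbon, and the step between them reads a 2.3-fold lower number from compound 2 to compound 3 (0.36 log units; beyond the scatter). Between compounds 2 and 1 the change is fluoro in place of methyl on an aromatic carbon, with a step of a 1.4-fold lower number from compound 2 to compound 1 (0.15 log units; within the scatter). The remaining pair gives a 1.6-fold lower number from compound 1 to compound 3 (0.20 log units; within the scatter), so compounds 1 and 3 cannot be told apart with confidence.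

Compound 4 `O=C(Nc1cccc(-c2oc3cc(-c4ccc(F)cc4)ccc3c(=O)c2O)c1)c1cccc(F)c1` has not yet been measured in this assay. It differs from compound 3 by fluoro in place of methyl on an aromatic carbon. Within the data shown here, this is the same kind of change as the one from compound 2 to compound 1, but not the same change: in the earlier pair the fluoro stands ortho to a large group, whereas in compound 4 it stands meta to a large group. The earlier instance, a 1.4-fold lower number from compound 2 to compound 1 (0.15 log units; within the scatter), stayed within the scatter of the measurement. Resting on that single precedent, for compound 4 the expected step is a 1.3-fold lower number from compound 3 to compound 4 (0.11 log units; within the scatter). The estimate for compound 4 in this assay is 8500 nM, and the number is expected to fall between 3500 nM and 20000 nM. Among the measured compounds shown here, no other compound here bears on this expectation, so it carries the uncertainty of a single comparison.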

Compound 4, half-maximal inhibitory concentration: 15800 nM
Beside the measured number, compound 4's estimate is 1.9-fold (0.27 log units) below it, within the range that was stated.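

In this assay, fluoro in place of methyl on the 3-methylphenyl group gives a 1.4-fold higher number from compound 3 to compound 4 (0.16 log units; within the scatter), and the other two new comparisons, a 1.6-fold lower number from compound 2 to compound 4 (0.20 log units; within the scatter) and a 1.1-fold lower number from compound 1 to compound 4 (0.04 log units; within the scatter), also stay within the scatter, so compound 4 cannot be told apart from any of the three earlier compounds. Set beside the earlier instance, the new step gives no sign that the change behaves differently from one core to the other: the same change on two cores in this assay, a 1.4-fold lower number (0.15 log units; within the scatter) from compound 2 to compound 1 and a 1.4-fold higher number (0.16 log units; within the scatter) from compound 3 to compound 4, 2.1-fold (0.32 log units) apart, within the scatter of two such steps. This shows that, in both pairs, the exchange of methyl for fluoro on the amide aryl ring left the number within the scatter, but it does not show that the change has a consistent direction or size, and two small steps cannot establish a rule for the series or for other positions.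

The compounds shown leave open what a larger change on this ring would do, such as an amine, a carboxylic acid or a longer chain in place of methyl or fluoro. They also leave open whether changes elsewhere on the shared core would move the number further than any exchange seen here, and whether the same holds in any other assay.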